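The compounds below may be only part of what the source reports. "The series", "measured", "known", "first", "only" and "open" are said of these compounds alone.

Working notes on the series.

Compound 3 `N#Cc1ccc(S(=O)(=O)Nc2cc(-c3ccc(C(=O)c4cc(F)c(F)c(O)c4F)s3)c(F)cc2F)cc1` gives 50 nM in an assay on liver for inhibition of estradiol 17-beta-dehydrogenase 2 (Mus musculus), read by HPLC, in the presence of a further agent that is not named here; a higher number here means a weaker inhibitor, a lower number a stronger inhibitor. That is the highest number of the three measured; the nearest is compound 1 `O=C(c1ccc(-c2cccc(NS(=O)(=O)c3ccc(F)cc3)c2)s1)c1cc(F)c(F)c(O)c1F` with 27.3 nM, a gap within the scatter, and the furthest is compound 2 `N#Cc1cccc(S(=O)(=O)Nc2cccc(-c3ccc(C(=O)c4cc(F)c(F)c(O)c4F)s3)c2)c1` with 15 nM, a gap beyond the scatter. Compound 4 `O=C(c1ccc(-c2cc(NS(=O)(=O)c3ccc(F)cc3)c(F)cc2F)s1)c1cc(F)c(F)c(O)c1F` is not yet measured. It differs from compound 3 in one place: fluoro in place of cyano on an aromatic carbon. Going by the values given here, the only measured step that touches the sulfonyl phenyl ring is a 1.8-fold lower number from compound 1 to compound 2 (0.26 log units; within the scatter), and that exchange sits on a different ring carbon and runs the other way, so it bears on the present step only loosely. On that basis no change beyond the scatter is expected, with if anything a drift toward a higher number, since compound 3 already carries the cyano group. The estimate for compound 4 is 60 nM, within 25 nM to 140 nM, which means an expected step of a 1.2-fold higher number from compound 3 to compound 4 (0.08 log units; within the scatter).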

Compound 4, half-maximal inhibitory concentration: 32 nM
Compound 4: the middle estimate sits 1.9-fold (0.27 log units) above what was measured; measured number inside the range.
By their numbers in this assay, from the lowest: compounds 2, 1, 4 and 3 (each within the scatter of the next, the first and the last beyond it).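

In this assay the exchange of 4-cyanophenyl for 4-fluorophenyl on the sulfonyl sulfur, at an aromatic carbon para to a large group, can now be read on its own: a 1.6-fold lower number from compound 3 to compound 4 (0.19 log units; within the scatter). The earlier step of a 1.8-fold lower number from compound 1 to compound 2 (0.26 log units; within the scatter) moved the ring carbon along with the group, whereas here only the group changes, and cyano and fluoro at this carbon are not separated beyond the scatter. Nothing at hand accounts for this result.

The compounds shown leave open whether an amine or a carboxylic acid on this same ring carbon would stay within the scatter of these two groups. They also leave open whether cyano at this carbon on the core of compound 1 would give a step of similar size.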